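A few compounds are considered here, and "the series" means these few. Any claim that something is new, unique, unknown or untested is made for them only; others in the source may bear on it.

Of the compounds shown here, three have been measured in a functional assay on PC-3 cells (Homo sapiens) for cytotoxicity, read by WST assay, with a stated time of 72 h; a higher number here means a weaker inhibitor, a lower number a stronger inhibitor. There, compound 1 `CCOc1ccc(C2(c3ccc(O)cc3)C(=O)Nc3c2ccc(F)c3F)cc1` gives 24 nM, compound 2 `COc1ccc(C2(c3cccc(O)c3)C(=O)Nc3c2ccc(F)c3F)cc1` gives 145 nM, and compound 3 `COc1ccc2c(c1C)NC(=O)C2(c1ccc(O)cc1)c1ccc(F)cc1` gives 9 nM. Compound 3 thus has the lowest number of the three, and its gaps to both of the others lie beyond the usual scatter. No two of these compounds differ in only one place, so the data hold no measured step that isolates a single change.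

Compound 4 `COc1ccc2c(c1C)NC(=O)C2(c1ccc(O)cc1)C1CCCCC1` departs from compound 3 in one place. It carries cyclohexyl in place of 4-fluorophenyl on a saturated ring carbon, two ring bonds from the ring nitrogen: cyclohexyl in place of 4-fluorophenyl on a saturated ring carbon. All three measured compounds keep two aromatic rings on that carbon, so none shows directly what this replacement does.

With compound 3 at the low end of the set and compound 2 at 145 nM marking the high end, a moderate weakening seems the likelier outcome, though a result close to compound 3 cannot be excluded. The expected change is a 5.0-fold higher number from compound 3 to compound 4 (0.70 log units; beyond the scatter), toward a higher number in this assay. For compound 4 the estimated value is 45 nM, with an expected range from 8 nM to 250 nM.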

Compound 4, half-maximal inhibitory concentration: 28 nM
Compound 4: middle estimate off by 1.6-fold (0.21 log units), on the high side, within the range that was stated.
By their numbers in this assay, from the lowest: compound 3; then compounds 1 and 4 (each within the scatter of the next); then compound 2.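

In this assay, replacing 4-fluorophenyl with cyclohexyl on the saturated ring carbon, two ring bonds from the ring nitrogen, gives a 3.1-fold higher number from compound 3 to compound 4 (0.49 log units; beyond the scatter). The step is modest but lies beyond the scatter. Unlike the earlier compounds, which all keep two aromatic rings on that carbon, compound 4 has only one there, alongside a six-membered non-aromatic ring of carbon only, and still gives 28 nM, so a second aromatic ring on this carbon is not needed for a value in this range. Nothing measured here accounts for the size of this step.

This single step also changes two things at once, removing the fluorine and replacing the aromatic ring with a non-aromatic one, and the compounds shown do not separate the two; a plain phenyl on this carbon would be the direct comparison. On these data alone, it also remains open how this carbon would tolerate a smaller ring such as cyclopentyl, an open chain such as butyl, or a ring containing an amine such as piperidinyl.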